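Dropping One Chloro From Compound 1

A few compounds are considered here, and "the series" means these few. Any claim that something is new, unique, unknown or untested is made for them only; others in the source may bear on it.

Measured compounds:
compound 1 `NC1=NC2(CCSCC2)N(OCCCOc2ccc(Cl)c(Cl)c2)C(N)=N1` gives 10 nM
compound 2 `NC1=NC2(CCOCC2)N(OCCCOc2ccc(Br)cc2)C(N)=N1` gives "not determined" (no result reported)

Within the data shown here, compound 1 is the only compound with a number in a functional assay on MDA-MB-231 cells (Homo sapiens) for antiproliferative activity, read by MTT assay, with a stated time of 72 h (on this read-out lower numbers stand for stronger inhibition and higher numbers for weaker inhibition), where compound 1 gives 10 nM; compound 2 carries no result in this assay, so nothing can be said of how the two compare. Compound 3 `NC1=NC2(CCSCC2)N(OCCCOc2ccc(Cl)cc2)C(N)=N1` differs from compound 1 in one place: hydrogen in place of chloro on an aromatic carbon. Among the measured compounds shown here, no pair of measured compounds differs in a single place, so no step size is known from the data themselves. On the structural change alone, a small loss of potency in this assay seems the more likely outcome, yet one that may still fall within the usual scatter. The step from compound 1 to compound 3 is expected to be a 2.5-fold higher number from compound 1 to compound 3 (0.40 log units; beyond the scatter). Compound 3 is therefore estimated at 25 nM, with a range from 8 nM to 80 nM.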

Compound 3, half-maximal inhibitory concentration: 350 nM
For compound 3 the middle estimate is 14-fold (1.15 log units) below the measured one; measured number outside the range, above it.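

In this assay, among these compounds, replacing chloro with hydrogen on the aromatic carbon gives a 35-fold higher number from compound 1 to compound 3 (1.54 log units; beyond the scatter), the first measured step. The earlier compounds offered no such comparison; this one shows that a single chlorine atom at this place, ortho to a chloro group and meta to a large group, accounts for a large share of the potency of compound 1 in this assay. Nothing at hand explains the size of this step.

The compounds shown leave open whether another group at this place, such as fluoro, methyl or methoxy, could stand in for the chloro and keep that potency. They also leave open whether removing the remaining chloro of compound 3 would cost as much again.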